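Furan-linked aryl series: methoxy replacing trifluoromethyl

The source may report more compounds than this note shows. Statements on the series, on what has been measured and on what is new or still open speak of the compounds shown alone.

Measured compounds:
- compound 1, `COC(=O)c1cccc(-c2ccc(CN(C)CCN)o2)c1`: 38%
- compound 2, `CN(CCN)Cc1ccc(-c2cccc(C(F)(F)F)c2)o1`: 31%

In an assay on cells for inhibition of protein arginine N-methyltransferase 1 (Homo sapiens), read by scintillation counting, with stated times of 15 min and 60 min, tested at 9 uM (on this read-out lower numbers stand for less inhibition and higher numbers for more inhibition at the one concentration tested (going by the name of the read-out)), compound 1 gives 38% and compound 2 gives 31%. For the measured compounds named here, the one measured step, a number 7 percentage points lower from compound 1 to compound 2 (within the scatter), is within the scatter, so the two numbers are not told apart. Compound 2 stands at the lower of the two numbers shown, with compound 1 as its only neighbour, and nothing separates them beyond the scatter.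

The next compound, compound 3, `COc1cccc(-c2ccc(CN(C)CCN)o2)c1`, differs from compound 2 in one place: methoxy in place of trifluoromethyl on an aromatic carbon. Going by the values given here, the only measured step concerns a different pair of groups on this aromatic carbon, methoxycarbonyl and trifluoromethyl, and that step was within the scatter. Among the compounds with values here, no measured step shows methoxy at this position, so there is no direct guide for the change to compound 3. Given that the one exchange at this carbon left the read-out within the scatter, the expectation is a step of a number 2 percentage points higher from compound 2 to compound 3 (within the scatter) that is not beyond the scatter either. Compound 3 is estimated at 33%, with a range from 18% to 48%.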

Compound 3, a percentage reported as inhibition, at one concentration (the size of the read-out at that concentration, not a potency): 24%
The estimate for compound 3 lay 9 percentage points above the measured number; low and high end bracket the measured number.
By their numbers in this assay, from the lowest: compounds 3, 2 and 1 (each within the scatter of the next, the first and the last beyond it).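

In this assay, for the compounds shown here, methoxy in place of trifluoromethyl gives a number 7 percentage points lower from compound 2 to compound 3 (within the scatter), so this exchange on the aromatic carbon does not separate the two groups, whereas methoxy in place of methoxycarbonyl gives a number 14 percentage points lower from compound 1 to compound 3 (beyond the scatter), the first step at this position that lies beyond the scatter. The position therefore does respond to the group it carries, but so far this is shown only for the pair methoxycarbonyl and methoxy, with trifluoromethyl in compound 2 not told apart from either of them. No available evidence accounts for the difference between compound 1 and compound 3.

Three groups on one aromatic carbon cannot show which feature of methoxycarbonyl goes with the separation from methoxy, and all three values come from a single concentration in one read-out. As far as these compounds go, how a carboxylic acid, an amine or a longer alkoxy chain on this same carbon would read remains open, as does whether methoxycarbonyl and methoxy would stay separated on another carbon of the six-membered aromatic ring.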